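Triazole side-chain swap on the benzyloxy butenolide core

The source may report more compounds than this note shows. Statements on the series, on what has been measured and on what is new or still open speak of the compounds shown alone.

Measured so far:
- compound 1 `O=C1O[C@H]([C@@H](O)Cn2cc(-c3cccc(O)c3)nn2)C(OCc2ccccc2)=C1OCc1ccccc1`: in a functional assay on HeLa cells (Homo sapiens) for antiproliferative activity, read by MTT assay, with a stated time of 72 h (a lower number here means a stronger inhibitor, a higher number a weaker inhibitor), compound 1 gives 39300 nM.
- compound 2 `COc1ccc(-c2cn(C/C=C3\OC(=O)C(OCc4ccccc4)=C3OCc3ccccc3)nn2)cc1`: in this assay compound 2 gives only a limit, > 100000 nM.

Within the data shown here, compound 1 holds the only numerical value in this assay; the other entry is the limit of > 100000 nM in this assay, at which 1 of the 2 values shown sits. Compound 3 `O=C1O[C@H]([C@@H](O)Cn2cc(CNS(=O)(=O)c3ccc(F)cc3)nn2)C(OCc2ccccc2)=C1OCc1ccccc1` keeps the core of compound 1 and differs by (((4-fluorophenyl)sulfonyl)amino)methyl in place of 3-hydroxyphenyl on an aromatic carbon. Among the measured compounds shown here, no measured step covers such a change, so no direction is supported. The step from compound 1 to compound 3 is expected to be a 1.1-fold higher number from compound 1 to compound 3 (0.06 log units; within the scatter), not beyond the scatter. Compound 3 is estimated at 45000 nM, between 12000 nM and 100000 nM.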

Compound 3, half-maximal inhibitory concentration: 25000 nM
For compound 3 the middle estimate is 1.8-fold (0.26 log units) above the measured one; the range from low to high includes it.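

Placing (((4-fluorophenyl)sulfonyl)amino)methyl instead of 3-hydroxyphenyl on this aromatic carbon gives, in this assay, a 1.6-fold lower number from compound 1 to compound 3 (0.20 log units; within the scatter). The two groups therefore cannot be told apart at this position, although the entering group is larger and brings a sulfur and a fluorine. Nothing at hand bears on why the two read alike.

From the compounds shown here alone, whether a small group on this carbon, such as a primary amine or a carboxylic acid, would read differently remains open. So does whether any change at this position moves the value beyond the scatter.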